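From sulfonyl to carbonyl on a ring nitrogen

This account rests on a few compounds, and the source may have more. Where it says the series, first, only, none or still open, it means among the compounds named here.

Measured so far in a physicochemical assay for lipophilicity, measured as octanol-water partition, at pH 7.4; on this read-out lower numbers stand for lower lipophilicity and higher numbers for higher lipophilicity:
- compound 1 `Cc1ccc2[nH]c(C(=O)N[C@H]3CCN(S(=O)(=O)c4cccnc4)C[C@@H]3C(=O)NCCN(C)C)cc2c1` gives 1.3
- compound 2 `Cc1ccc2[nH]c(C(=O)N[C@H]3CCN(S(=O)(=O)N4CCOCC4)C[C@@H]3C(=O)NCCN(C)C)cc2c1` gives 1
- compound 3 `Cc1ccc2[nH]c(C(=O)N[C@H]3CCN(S(=O)(=O)N(C)C)C[C@@H]3C(=O)NCCN(C)C)cc2c1` gives 1.2

Compound 3, with 1.2 on this scale, lies within the usual scatter of both other compounds, so the three cannot be ranked. Compound 4 `Cc1ccc2[nH]c(C(=O)N[C@H]3CCN(C(=O)c4cccnc4)C[C@@H]3C(=O)NCCN(C)C)cc2c1` differs from compound 3 in one place: (pyridin-3-yl)carbonyl in place of dimethylsulfamoyl on an amine nitrogen in a ring. The nearest evidence is the exchange of groups on the sulfonyl sulfur, which gave only small steps: a number 0.10 log units lower from compound 1 to compound 3 (within the scatter) and a number 0.20 log units higher from compound 2 to compound 3 (within the scatter). Among the compounds with values here, no measured step replaces a sulfonyl with a carbonyl, so the evidence is indirect. A small fall, no larger than the scatter, is expected in this assay. The estimated change is a number 0.30 log units lower from compound 3 to compound 4 (within the scatter) in this expectation. For compound 4 the estimate is 0.9 with an expected range from 0.5 to 1.3 as its limits.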

Compound 4, distribution coefficient: 0.7
Beside the measured number, compound 4's estimate is 0.20 log units above it, within the range that was stated.
By their numbers in this assay, from the lowest: compounds 4, 2, 3 and 1 (each within the scatter of the next, the first and the last beyond it).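

The sulfonyl-to-carbonyl exchange reaches beyond the scatter, which no exchange on the sulfonyl sulfur did. With pyridin-3-yl kept in place, the change gives a number 0.60 log units lower from compound 1 to compound 4 (beyond the scatter) in this assay, and the step from the dimethylsulfamoyl compound gives a number 0.50 log units lower from compound 3 to compound 4 (beyond the scatter) as well. The morpholine-bearing comparison is less clear, with a number 0.30 log units lower from compound 2 to compound 4 (within the scatter) and two groups differing at once; no measurement shown explains these steps.

From the compounds shown here alone, whether the same step holds with a phenyl ring or a methyl group on the carbonyl stays open. So does the value of the ring amine with a simple ethyl group on its nitrogen.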